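A few compounds are considered here, and "the series" means these few. Any claim that something is new, unique, unknown or untested is made for them only; others in the source may bear on it.

Compound 3 `C[C@@H]1CC[C@@H](C)N1CCCOc1ccc(-c2ccc(C#N)cc2)cc1` stands lowest of the three numbers in an assay on isolated protein for binding affinity to histamine H2 receptor (Homo sapiens) (a lower number here means a stronger inhibitor, a higher number a weaker inhibitor), where compound 3 gives 9120 nM. Its nearest neighbour is compound 2 `CCOC(=O)N1CCN(CCCOc2ccc(-c3cccs3)cc2)CC1`, which in this assay gives 33100 nM; furthest away is compound 1 `CCOC(=O)N1CCN(CCCOc2ccc(-c3c[nH]cn3)cc2)CC1`, which in this assay gives 69200 nM. Going by the values given here, the single step that joins two measured compounds, a 2.1-fold lower number from compound 1 to compound 2 (0.32 log units; beyond the scatter), alters the aromatic ring at the far end of the molecule and leaves the amine end as it is.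

Compound 4 `N#Cc1ccc(-c2ccc(OCCCN3CCNCC3)cc2)cc1` differs from compound 3 at that amine end: piperazin-1-yl in place of 2,5-dimethylpyrrolidin-1-yl on a saturated chain carbon, three bonds along the chain from an oxygen on an aromatic ring. Among the compounds with values here, no measured pair isolates this change. Compounds 1 and 2 carry a substituted piperazine and also a different aromatic end from compound 3, so the gap between compound 2 and compound 3 mixes two changes and cannot be read as a step for the amine alone. Within the data shown here, the only measured step is modest, and nothing in the data points to a large swing in either direction. The account therefore expects a step of a 1.6-fold higher number from compound 3 to compound 4 (0.22 log units; within the scatter) for compound 4, toward a somewhat higher number, but with little confidence. For compound 4 the estimate in this assay is 15000 nM, within a range from 4000 nM to 60000 nM.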

Compound 4, inhibition constant: 22900 nM
Beside the measured number, compound 4's estimate is 1.5-fold (0.18 log units) below it, and the stated range covers the measured number.
By their numbers in this assay, from the lowest: compound 3; then compounds 4 and 2 (each within the scatter of the next); then compound 1.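

With the aromatic end bearing the nitrile held fixed, the amine end can now be read on its own in this assay: piperazin-1-yl in place of 2,5-dimethylpyrrolidin-1-yl gives a 2.5-fold higher number from compound 3 to compound 4 (0.40 log units; beyond the scatter), a modest step that shows this position, on a saturated chain carbon, three bonds along the chain from an oxygen on an aromatic ring, responds to a change of amine, which the earlier step at the aromatic end could not show. The step bundles several differences, as the ring size, the ring hetero atoms, the hydrogen-bond donor and the 2 defined stereocentres all change together, so it cannot be assigned to any one of them. No supporting information on hand accounts for the size or direction of this step.

The compounds shown leave open whether the two methyl groups or the ring itself carry the difference, a question that an unsubstituted pyrrolidin-1-yl or a piperidin-1-yl at this position would address. They also leave open whether the same amine change gives a similar step when the aromatic end is thiophen-2-yl or 1H-imidazol-4-yl.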